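Carbamoyl in Place of Benzyloxycarbonyl on a Shared Core

The source may hold more compounds than are shown below. What is called first, only, known or untested is meant among the compounds shown, and "the series" means these compounds.

Of the compounds shown here, three on the same core have been tested in a functional assay on HEL cells (Homo sapiens) for cytotoxicity, read by microscopy; on this read-out lower numbers stand for higher toxicity in this test and higher numbers for lower toxicity in this test. Compound 1 `Cc1cn([C@@H]2O[C@H](CO[Si](C)(C)C(C)(C)C)[C@@]3(OS(=O)(=O)C=C3NCC(=O)C(=O)N3CCC3)[C@H]2O[Si](C)(C)C(C)(C)C)c(=O)n(C)c1=O` gives 65000 nM in this assay. Compound 2 `COC(=O)CC(=O)NC1=CS(=O)(=O)O[C@@]12[C@@H](CO[Si](C)(C)C(C)(C)C)O[C@@H](n1cc(C)c(=O)n(C)c1=O)[C@@H]2O[Si](C)(C)C(C)(C)C` gives 400000 nM. Compound 3 `Cc1cn([C@@H]2O[C@H](CO[Si](C)(C)C(C)(C)C)[C@@]3(OS(=O)(=O)C=C3NCCC(=O)OCc3ccccc3)[C@H]2O[Si](C)(C)C(C)(C)C)c(=O)n(C)c1=O` reaches only a limit of this assay, reported as >= 400000 nM, so its true number is not known. The measured steps read as follows: a 6.2-fold higher number from compound 1 to compound 2 (0.79 log units; beyond the scatter), an at least 6.1-fold higher number from compound 1 to compound 3 (0.78 log units; beyond the scatter), and a number no lower from compound 2 to compound 3 (the limit leaves the size open). Compound 3 thus stands at the upper edge of what the assay reports, as the evidence shows: the limit of >= 400000 nM in this assay, at which 1 of the 3 values shown sits.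

Compound 4 `Cc1cn([C@@H]2O[C@H](CO[Si](C)(C)C(C)(C)C)[C@@]3(OS(=O)(=O)C=C3NCCC(N)=O)[C@H]2O[Si](C)(C)C(C)(C)C)c(=O)n(C)c1=O` differs from compound 3 by amino in place of benzyloxy on a carbonyl carbon. Within the data shown here, no measured step changes this same position, so the prior steps only set the surroundings: the whole series lies in a weakly toxic range, and compound 3 is already at the limit. One step of the kind seen between compound 1 and compound 2 would not be readable from a limit. The number for compound 4 is therefore expected to stay near the limit, with an expected step of a number no higher from compound 3 to compound 4 (the limit leaves the size open). Compound 4 is estimated at 400000 nM in this assay, in a range from 150000 nM to 1000000 nM, with a fair chance that only a limit is reported again.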

Compound 4, minimum cytotoxic concentration: >= 80000 nM
Compound 4 ended at the assay's limit (the forecaster's own chance of this, stated with the estimate: 55%); the middle value is on the limit's open side.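

In this assay compound 4 gives only a limit, >= 80000 nM, so the first change shown on this carbonyl carbon, amino in place of benzyloxy, ends without a measured number on either side. The steps from compound 3 and from compound 2 to compound 4 cannot be read, which means that losing the benzyloxy group with its six-membered aromatic ring is not shown to move the read-out in either direction. The one step that can be read is an at least 1.2-fold higher number from compound 1 to compound 4 (0.09 log units; that floor lies within the scatter), so the carbamoylmethyl group in place of ((azetidin-1-yl)carbonyl)carbonyl is not shown to separate compound 4 from compound 1, although the limit leaves room for a larger gap.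

The compounds shown leave open whether benzyloxycarbonyl and carbamoyl differ at all in this assay, and a measured number for compound 3 and for compound 4 would be needed to settle it. They also leave open how a carboxylic acid on this carbonyl carbon, or a longer chain carrying the carbamoyl group, would read on the shared core.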